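From a Non-Aromatic to an Aromatic Ring on Nitrogen

A few compounds are considered here, and "the series" means these few. Any claim that something is new, unique, unknown or untested is made for them only; others in the source may bear on it.

Of the compounds shown here, three have been measured so far in a functional assay on Shh Light II cells (Mus musculus) for inhibition, read by a luciferase reporter (on this read-out lower numbers stand for stronger inhibition and higher numbers for weaker inhibition), and they spread widely. Compound 2 `O=C(NC1CCS(=O)(=O)CC1)N1CCC(c2nc(-c3ccc4ccccc4n3)no2)CC1` stands in the middle with 360 nM as its value. Compound 3 `Cn1c(-c2noc(C3CCN(C(=O)NC4CCCCC4)CC3)n2)nc2ccccc21` gives a lower number at 89 nM and compound 1 `C[C@@H]1C[C@H](c2nc(-c3ccc4ccccc4n3)no2)CCN1C(=O)Nc1ccccc1Cl` gives a higher one at 2400 nM with both gaps from compound 2 lying beyond the scatter.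

Compound 4 `O=C(Nc1ccccc1C(F)(F)F)N1CCC(c2nc(-c3ccc4ccccc4n3)no2)CC1` is still unmeasured. Among the measured compounds shown here, it keeps the core of compound 2 but carries 2-(trifluoromethyl)phenyl in place of 1,1-dioxothian-4-yl on an amide-type nitrogen as its only change.

For the measured compounds named here, no measured pair shows this change alone, so any forecast is rough. Among the measured compounds, only compound 1 has a six-membered aromatic ring of carbon only on that nitrogen, although it differs from compound 4 elsewhere too. Compound 1 reads 2400 nM in this assay and this suggests a move towards weaker inhibition. The expected change is a 2.2-fold higher number from compound 2 to compound 4 (0.35 log units; beyond the scatter) and it should be a moderate rise. For compound 4 the estimated value is 800 nM with an expected range from 200 nM to 3000 nM as the likely span.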

Compound 4, half-maximal inhibitory concentration: 700 nM
The estimate for compound 4 lay 1.1-fold (0.06 log units) above the measured number, within the range that was stated.
By their numbers in this assay, from the lowest: compound 3; then compounds 2 and 4 (each within the scatter of the next); then compound 1.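

In this assay, the amide-type nitrogen accepts two very different groups with little consequence, as exchanging 1,1-dioxothian-4-yl for 2-(trifluoromethyl)phenyl gives a 1.9-fold higher number from compound 2 to compound 4 (0.29 log units; within the scatter). Among the compounds shown here, this is the first reading of this position with the rest of the molecule held constant: a six-membered non-aromatic ring with 2 hydrogen-bond acceptors and a six-membered aromatic ring of carbon only with 0 acceptors give values within the scatter of each other. No supporting measurement accounts for this similarity.

From the compounds shown here alone, it remains open whether the trifluoromethyl group contributes anything, which a plain phenyl ring on this nitrogen would help to test. A 2-aminoethyl chain at the same place would show whether a group without any ring is also accepted.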